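The source may report more compounds than this note shows. Statements on the series, on what has been measured and on what is new or still open speak of the compounds shown alone.

Compound 2 `O=C1N(CCCCCCOc2ccc(Br)cc2)CCN1c1ccnc(Cl)c1` is the starting point here. In a functional assay on cells (Homo sapiens) for cytotoxicity (a lower number here means that less compound is tolerated, a higher number that more compound is tolerated), compound 2 gives > 25000 nM, which is a limit of the assay. Its two closest relatives are compound 1 `O=C1N(CCCCCCOc2ccc(Br)cc2)CCN1c1ccncc1` and compound 3 `O=C1N(CCCCCCOc2ccc(C(F)(F)F)cc2)CCN1c1ccnc(Cl)c1`. Compound 1 gives > 25000 nM in this assay, again a limit. Compound 3 gives > 25000 nM in this assay, also a limit. The step from compound 1 to compound 2 is a step that the two limits leave unreadable from compound 1 to compound 2, and the step from compound 2 to compound 3 is a step that the two limits leave unreadable from compound 2 to compound 3. Both steps are unreadable because of the limit of > 25000 nM in this assay, at which 3 of the 3 values shown sit. Compound 4 `O=C1N(CCCCCOc2ccc(Br)cc2)CCN1c1ccnc(Cl)c1` has not yet been measured; it differs from compound 2 by 4-bromophenoxy in place of (4-bromophenoxy)methyl on a saturated chain carbon, five bonds along the chain from an amide-type nitrogen in a ring. Neither measured step touches the length of this chain, and the three values carry no size that could be transferred to the new change. The expected step from compound 2 to compound 4 is therefore a number no higher from compound 2 to compound 4 (the limit leaves the size open), which is to say nothing beyond the scatter. Compound 4 is estimated at 25000 nM, within a range from 10000 nM to 60000 nM, and it is expected that the assay again reports only a limit.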

Compound 4, half-maximal cytotoxic concentration: > 25000 nM
Compound 4 gave a limit, no number; the forecaster's own chance of this, stated with the estimate: 85%; the middle value sits exactly at the limit.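

No size can be read for the step between compound 2 and compound 4, because both compounds give only a limit of the assay, not a number: the limit of > 25000 nM in this assay, at which 4 of the 4 values shown sit.

The compounds shown leave open whether any of these changes, including the shorter chain, alters the result in this assay at all.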